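The compounds below may be only part of what the source reports. "The series", "measured", "known", "first", "only" and "open" are said of these compounds alone.

Compound 1 `C#CCN(CCC)Cc1cn(-c2cc(NC(=S)NCC)ncn2)cn1`: in an assay on isolated protein for inhibition of Amine oxidase [flavin-containing] B (Homo sapiens), read by fluorescence and Amplex Red, with a stated time of 15 min (on this read-out higher numbers stand for weaker inhibition and lower numbers for stronger inhibition), compound 1 gives > 50000 nM, which is a limit of the assay rather than a number.
Compound 2 `C#CCN(Cc1cn(-c2cc(NC(=S)NCC)ncn2)cn1)C(C)=O`: in this assay compound 2 gives > 50000 nM, again a limit.
Compound 3 `C#CCN(CC#N)Cc1cn(-c2cc(NC(=S)NCC)ncn2)cn1`: in this assay compound 3 gives > 50000 nM, also a limit.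

Compound 3 thus stands only at a limit in this assay, and so do its two neighbours, as summed up by the limit of > 50000 nM in this assay, at which 3 of the 3 values shown sit. The three steps between the measured compounds, a step that the two limits leave unreadable from compound 1 to compound 2, a step that the two limits leave unreadable from compound 1 to compound 3 and a step that the two limits leave unreadable from compound 2 to compound 3, cannot be read; both ends of each sit at the same limit, so neither their size nor their direction is known.

Compound 4 `C#CCN(CC#C)Cc1cn(-c2cc(NC(=S)NCC)ncn2)cn1` differs from compound 3 by ethynyl in place of cyano on a saturated chain carbon bound to an amine nitrogen. Every measured step that bears on the amine substituent is unreadable, so nothing in the shown numbers points in either direction, and compound 1, which already carries a propargyl group on the amine nitrogen, sits at the limit too. Compound 4 is therefore expected to give 50000 nM in this assay, within 10000 nM to 200000 nM, most probably reported once more only as a limit. The step of a number no higher from compound 3 to compound 4 (the limit leaves the size open) is expected to be none beyond the scatter.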

Compound 4, half-maximal inhibitory concentration: > 50000 nM
Compound 4 ended at the assay's limit (the forecaster's own chance of this, stated with the estimate: 70%); the middle value sits exactly at the limit.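

None of the steps from compound 1, compound 2 or compound 3 to compound 4 can be read in this assay, because all four compounds stand at a limit: the limit of > 50000 nM in this assay, at which 4 of the 4 values shown sit.

The compounds shown leave open how strongly any of them inhibits, and whether changing the amine nitrogen substituent alters inhibition at all.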